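From (tert-butyl)amino to propylamino: working notes on the series

The source may hold more compounds than are shown below. What is called first, only, known or untested is meant among the compounds shown, and "the series" means these compounds.

Measured so far in a physicochemical assay for solubility, in phosphate buffer, at pH 6.8; a lower number here means a less soluble compound, a higher number a more soluble compound 
- compound 1 `CCn1c(NC(C)(C)C)nc2ccsc2c1=O` gives 3.7 ug/mL 
- compound 2 `CCn1c(N[C@H]2CC[C@H](C(=O)OC)CC2)nc2ccsc2c1=O` gives 13 ug/mL 
- compound 3 `CCn1c(NC(C)C)nc2c(-c3cccnc3)csc2c1=O` gives 5.8 ug/mL 

Compound 1 and compound 3 lie within the scatter of each other, while compound 2 stands above compound 1 by more than the scatter. Compound 1 therefore belongs to the lower pair of this small set, without being separated from compound 3.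

Compound 4 `CCCNc1nc2ccsc2c(=O)n1CC` has not yet been measured. It carries propyl in place of tert-butyl on a nitrogen on an aromatic ring. For the measured compounds named here, none of the measured compounds form a pair that differs in one place, so no measured step guides the size of this change.

In this assay no step beyond the scatter is expected, with only a slight lean towards a higher number. The expectation starts from compound 1 at 3.7 ug/mL and its range is kept wide enough to reach compound 2 at 13 ug/mL on the upper side. The estimated step (a 1.5-fold higher number from compound 1 to compound 4 (0.17 log units; within the scatter)) stays within the scatter. Compound 4 is expected at 5.5 ug/mL (estimated range 2.2 ug/mL to 14 ug/mL).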

Compound 4, solubility: 69 ug/mL
The estimate for compound 4 lay 13-fold (1.10 log units) below the measured number; the measured number lies above the stated range.
By their numbers in this assay, from the lowest: compounds 1 and 3 (each within the scatter of the next); then compound 2; then compound 4.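

In this assay, for the compounds shown here, propyl in place of tert-butyl on a nitrogen on an aromatic ring gives a 19-fold higher number from compound 1 to compound 4 (1.27 log units; beyond the scatter), the only step that can be read across a single place, and it lies well beyond the scatter. This position is therefore not indifferent to the choice of alkyl group: neither group carries a ring, a hydrogen-bond donor or acceptor, or a net charge, so a large step here does not depend on any of these features changing. Nothing measured on these compounds accounts for the size of the step, and its origin stays unassigned.

Going by these compounds, with one pair at this position, it remains open whether the step follows from the straight chain itself or from the removal of tert-butyl, and a longer chain such as butyl or a small ring such as cyclopropyl would sit differently against that question. On these data alone, it also remains open whether the same change gives a step of similar size when the rest of the molecule differs from compound 1.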